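A few compounds are considered here, and "the series" means these few. Any claim that something is new, unique, unknown or untested is made for them only; others in the source may bear on it.

Measured so far:
Compound 1 `Cc1cc2c(C(C)C)ccc(C)c2cc1OC(=O)c1cccc(C(F)(F)F)c1`: "not active" (no number reported)
Compound 2 `Cc1cc2c(C(C)C)ccc(C)c2cc1OC(=O)c1ccc(C(F)(F)F)cc1`: 16.5%
Compound 3 `COc1cccc(C(=O)Oc2cc3c(C)ccc(C(C)C)c3cc2C)c1`: "not active" (no number reported)

In a functional assay on U-251 cells (Homo sapiens) for antiproliferative activity, read by sulforhodamine B assay, with a stated time of 48 h, tested at 50 uM (on this read-out higher numbers stand for more inhibition at the one concentration tested (going by the name of the read-out) and lower numbers for less inhibition), compound 2 gives 16.5%. Compound 1 gives "not active" (no number reported) and compound 3 gives "not active" (no number reported) in this assay, so no single number stands for compound 3: it is one of two compounds without a number, and nothing on the numbers shown sets it apart from compound 1. Compound 4 `Cc1cc2c(C(C)C)ccc(C)c2cc1OC(=O)c1ccc([N+](=O)[O-])cc1` is the untested compound; compared with compound 3, (4-nitrophenyl in place of 3-methoxyphenyl on a carbonyl carbon). Going by the values given here, no step between measured compounds covers a change of this kind, and compound 2 shows that a different group on a carbonyl carbon reaches only a modest reading in this assay. A small step at most is expected here, in either direction, with a fair chance that again no number is reported. Compound 4 is expected to give 12%, within 0% to 30%.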

Compound 4, a percentage reported as inhibition, at one concentration (the size of the read-out at that concentration, not a potency): 100%
Beside the measured number, compound 4's estimate is 88 percentage points below it, and the stated range ends below it.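

In this assay, nitro in place of trifluoromethyl on an aromatic carbon gives a number 83.5 percentage points higher from compound 2 to compound 4 (beyond the scatter). The earlier compounds shown here gave only a modest reading or none, whereas this pair shows that one change on the aromatic ring, with the rest of the structure held the same, can transform the result. No measurement at hand explains this step. From the compounds shown here alone, whether an amine or a carboxylic acid in place of nitro would give a similar reading remains open. A reading at one concentration also leaves the potency of compound 4 unknown.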